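Stilbene analogues with a varied pendant aryl ring

This account rests on a few compounds, and the source may have more. Where it says the series, first, only, none or still open, it means among the compounds named here.

Three stilbenes sharing one core have been measured for cytotoxicity in a functional assay on HeLa cells (Homo sapiens) for cytotoxicity, read by MTT assay, with a stated time of 48 h; a higher number here means a weaker inhibitor, a lower number a stronger inhibitor. Compound 1 `COc1ccc(/C=C/c2cc(OC)c(OC)c(OC)c2-c2ccc(OC)cc2)cc1` gives 19000 nM, compound 2 `COc1ccc(/C=C/c2cc(OC)c(OC)c(OC)c2-c2ccc(F)c(F)c2)cc1` gives 9200 nM, and compound 3 `COc1ccc(/C=C/c2cc(OC)c(OC)c(OC)c2-c2ccc(Cl)cc2)cc1` gives 49000 nM. Among these three, compound 2 shows the lowest number, with a 2.1-fold lower number from compound 1 to compound 2 (0.31 log units; beyond the scatter) and a 5.3-fold higher number from compound 2 to compound 3 (0.73 log units; beyond the scatter), and between the other two there is a 2.6-fold higher number from compound 1 to compound 3 (0.41 log units; beyond the scatter).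

Compound 4 `COc1ccc(/C=C/c2cc(OC)c(OC)c(OC)c2-c2ccc(OC)c(OC)c2)cc1` carries a different pendant ring. The change relative to compound 2 is 3,4-dimethoxyphenyl in place of 3,4-difluorophenyl on an aromatic carbon. Among the measured compounds shown here, the step that bears most directly on it is the one leading to compound 2, where a 2.1-fold lower number from compound 1 to compound 2 (0.31 log units; beyond the scatter); the change to compound 4 runs the other way, from a fluorinated ring back to a methoxy-bearing one, while the only other pendant-ring change, a 5.3-fold higher number from compound 2 to compound 3 (0.73 log units; beyond the scatter), also gave a higher number. A modest rise in the number, of about the size seen for compound 1, is therefore expected.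

Compound 4 is estimated to give 20000 nM in this assay, within a range of 7000 nM to 60000 nM, which would mean an expected step of a 2.2-fold higher number from compound 2 to compound 4 (0.34 log units; beyond the scatter).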

Compound 4, half-maximal inhibitory concentration: 45000 nM
For compound 4 the middle estimate is 2.3-fold (0.35 log units) below the measured one; the measured number falls inside the stated range.
By their numbers in this assay, from the lowest: compound 2; then compound 1; then compounds 4 and 3 (each within the scatter of the next).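

Putting 3,4-dimethoxyphenyl in place of 3,4-difluorophenyl on this aromatic carbon gives a 4.9-fold higher number from compound 2 to compound 4 (0.69 log units; beyond the scatter) in this assay, so these two pendant rings are not interchangeable here. Methoxy in place of hydrogen on the pendant ring of compound 1 gives a 2.4-fold higher number from compound 1 to compound 4 (0.37 log units; beyond the scatter), so adding this group did not lower the number, whereas the change from compound 1 to the difluorinated ring of compound 2 did. The 4-chlorophenyl and 3,4-dimethoxyphenyl rings are not told apart, with a 1.1-fold lower number from compound 3 to compound 4 (0.04 log units; within the scatter), and compound 2 remains the only one of the four set apart from all the others at the low end.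

Nothing available explains these steps. Going by these compounds, it remains open how a pendant ring carrying a single fluoro group, an amine or a carboxylic acid would compare with compound 2.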